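The source may report more compounds than this note shows. Statements on the series, on what has been measured and on what is new or still open speak of the compounds shown alone.

Compound 1, `CC(=O)c1ccc(CSc2nc(Cc3cc(C)cc(C)c3)c(I)c(=O)[nH]2)cc1`, was tested in an ADME assay on HepG2 2.2.15 cells (Homo sapiens) for cytotoxicity, read by MTT assay, with a stated time of 72 h (a lower number here means that less compound is tolerated, a higher number that more compound is tolerated), where compound 1 gives 78300 nM. Two companions share its core. Compound 2, `O=c1[nH]c(SCc2ccc([N+](=O)[O-])cc2)nc(Cc2ccccc2)c1I`, gives 52700 nM in this assay, and compound 3, `Cc1cc(C)cc(Cc2nc(SCCOc3ccc([N+](=O)[O-])cc3)[nH]c(=O)c2I)c1`, gives 96600 nM. Among these three numbers compound 1 stands second highest, but its gaps to compound 3 and to compound 2 both lie within the usual scatter, so no order of tolerance can be read from them.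

Compound 4, `Cc1cc(C)cc(Cc2nc(SCc3ccc(C#N)cc3)[nH]c(=O)c2I)c1`, has not yet been measured. It differs from compound 1 in one place: cyano in place of acetyl on an aromatic carbon. Among the compounds with values here, no pair of measured compounds differing in only one place is available here, so there is no measured step to lean on for this change. The expectation is therefore modest: the step of a 1.0-fold lower number from compound 1 to compound 4 (0.00 log units; within the scatter) is expected to remain within the scatter. Compound 4 is estimated at 78000 nM, with a likely range from 35000 nM to 170000 nM.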

Compound 4, half-maximal cytotoxic concentration: 43200 nM
The estimate for compound 4 lay 1.8-fold (0.26 log units) above the measured number, within the range that was stated.
By their numbers in this assay, from the lowest: compounds 4, 2, 1 and 3 (each within the scatter of the next, the first and the last beyond it).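

In this assay, within the data shown here, the exchange of 4-acetylphenyl for 4-cyanophenyl gives the first step that can be read at this position, on an aromatic carbon para to a large group: a 1.8-fold lower number from compound 1 to compound 4 (0.26 log units; within the scatter). Since this step lies within the scatter, the two compounds cannot be told apart, and this measurement gives no sign that tolerance depends on whether acetyl or cyano occupies this place. Nothing measured here accounts for the number found for compound 4.

From the compounds shown here alone, whether a group of a different kind on the same aromatic carbon, such as an amine or a carboxylic acid, would produce a step beyond the scatter remains open. A single pair also cannot show whether the same exchange would give a similar step on another compound with the shared core.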